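From Fluoro to Cyano on the Benzyl Group

The source may report more compounds than this note shows. Statements on the series, on what has been measured and on what is new or still open speak of the compounds shown alone.

compound 1 `CC(C)(C)c1cc(CCC(=O)NC2CCN(Cc3ccccc3)CC2)cc(C(C)(C)C)c1O`: 80300 nM
compound 2 `CC(C)(C)c1cc(CCC(=O)NCC2CCN(Cc3ccccc3)CC2)cc(C(C)(C)C)c1O`: 63400 nM
compound 3 `CC(C)(C)c1cc(/C=C/C(=O)NCCC2CCN(Cc3ccc(F)cc3)CC2)cc(C(C)(C)C)c1O`: 57500 nM

All three values come from a functional assay, read by spectrophotometry, with a stated time of 30 min (a higher number here means a weaker inhibitor, a lower number a stronger inhibitor), and lie close together. In this assay compound 3 gives 57500 nM and stands within the scatter of both compound 2 (63400 nM) and compound 1 (80300 nM), so the three cannot be ranked.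

Compound 4 `CC(C)(C)c1cc(/C=C/C(=O)NCCC2CCN(Cc3ccc(C#N)cc3)CC2)cc(C(C)(C)C)c1O` has not yet been measured. It differs from compound 3 in a single place, where 4-fluorobenzyl becomes 4-cyanobenzyl: cyano in place of fluoro on an aromatic carbon, para to a large group (cyano in place of fluoro on an aromatic carbon). Within the data shown here, no two measured compounds differ in one place only, so the data offer no direct precedent for this exchange. Among the measured compounds shown here, the only guide is the narrow spread of the measured values, and nothing points to a particular direction. A step of a 1.0-fold lower number from compound 3 to compound 4 (0.02 log units; within the scatter) is expected that stays within the scatter. Compound 4 is estimated at 55000 nM (expected range 24000 nM to 110000 nM).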

Compound 4, half-maximal inhibitory concentration: 79500 nM
The estimate for compound 4 lay 1.4-fold (0.16 log units) below the measured number, and the stated range covers the measured number.
By their numbers in this assay, from the lowest: compounds 3, 2, 4 and 1 (each within the scatter of the next).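

Among these compounds, the exchange of 4-fluorobenzyl for 4-cyanobenzyl gives the first step that can be read at a single place, and in this assay it amounts to a 1.4-fold higher number from compound 3 to compound 4 (0.14 log units; within the scatter). At this position on the aromatic ring, para to a large group, cyano with its 2 heavy atoms and 1 hydrogen-bond acceptor can therefore stand in place of fluoro without a change that exceeds the scatter. No measurement at hand offers an explanation for this result.

As far as these compounds go, whether an amine or a carboxylic acid at this place would give a number beyond the scatter remains open. The role of the chain linking the amide to the core also stays unresolved, since compounds 1 and 2 differ from compound 3 and compound 4 in more than one place.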